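Cytotoxicity Limits Across Two Measured Compounds and a Third

A few compounds are considered here, and "the series" means these few. Any claim that something is new, unique, unknown or untested is made for them only; others in the source may bear on it.

Compound 1 `CC(C)N(Cc1cccc(OCCCCCC(=O)O)c1)C(=O)c1ccc(-c2ccncc2)cc1` in an ADME assay on HepG2 cells (Homo sapiens) for cytotoxicity, read by CellTiter-Glo and resazurin assay, with a stated time of 72 h; a lower number here means that less compound is needed, a higher number that more compound is needed for the effect: > 26000 nM
Compound 2 `CC(C)Oc1cccc(-c2ccc(C(=O)N(Cc3cccc(OCCCCCC(=O)O)c3)C(C)C)cc2)c1` in this assay: > 26000 nM

In this assay compound 1 gives > 26000 nM, which is a limit of the assay and not a number. In this assay compound 2 gives > 26000 nM, likewise only a limit. The step that the two limits leave unreadable from compound 1 to compound 2 is therefore unreadable in size and direction. Going by the values given here, compound 2 thus stands at the limit of > 26000 nM in this assay, at which 2 of the 2 values shown sit, the same place where every value so far sits.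

Compound 3 `CC(C)N(Cc1cccc(OCCCCCC(=O)O)c1)C(=O)c1ccc(-c2ccc3[nH]ccc3c2)cc1` differs from compound 2 in one place: 1H-indol-5-yl in place of 3-isopropoxyphenyl on an aromatic carbon. Among the compounds with values here, the only measured step that bears on this change is a step that the two limits leave unreadable from compound 1 to compound 2, and it gives no readable size, so nothing in the data points to a step beyond the scatter. Compound 3 is therefore expected to return another limit, estimated at 30000 nM with a range from 13000 nM to 80000 nM. The expected step that the limit leaves unreadable from compound 2 to compound 3 is estimated to lie within the scatter.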

Compound 3, half-maximal effective concentration: > 26000 nM
Compound 3: only a limit was reported; the forecaster's own chance of this, stated with the estimate: 85%; the middle value lies beyond the limit too.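

In this assay compound 3 gives > 26000 nM, again a limit of the assay and not a number, so no step among compound 1, compound 2 and compound 3 can be read: the limit of > 26000 nM in this assay, at which 3 of the 3 values shown sit.

The compounds shown leave open whether pyridin-4-yl, 3-isopropoxyphenyl and 1H-indol-5-yl differ at all in this assay, and at what concentration any of these compounds would reach the half-maximal effect.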